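The compounds below may be only part of what the source reports. "The series", "measured", "known", "first", "only" and "open" are said of these compounds alone.

Measured so far:
- compound 1 `COC(=O)c1cccc(OC)c1OC(=O)COc1cc(O)c2c(=O)cc(-c3ccccc3)oc2c1` — 36800 nM
- compound 2 `COC(=O)c1cccc(C)c1OC(=O)COc1cc(O)c2c(=O)cc(-c3ccccc3)oc2c1` — 39100 nM

In a functional assay on cells (T-cell, Mus musculus, strain BALB/c) for inhibition, read by MTT assay, with a stated time of 72 h (on this read-out lower numbers stand for stronger inhibition and higher numbers for weaker inhibition), compound 2 holds the higher of the two numbers, but its gap to compound 1 is within the scatter: a 1.1-fold higher number from compound 1 to compound 2 (0.03 log units; within the scatter). Compound 3 `COC(=O)c1cc(Br)ccc1OC(=O)COc1cc(O)c2c(=O)cc(-c3ccccc3)oc2c1` differs from compound 2 by a group of 11 heavy atoms (8 carbon, 2 oxygen, 1 bromine; one six-membered aromatic ring of carbon only) in place of a group of 11 heavy atoms (9 carbon, 2 oxygen; one six-membered aromatic ring of carbon only), on an oxygen next to a carbonyl group. Going by the values given here, the single measured step, a 1.1-fold higher number from compound 1 to compound 2 (0.03 log units; within the scatter), touches a different part of the ester-bearing ring and gave no change beyond the scatter; no measured step bears directly on the present change. The step to compound 3 is therefore expected to be a 1.0-fold lower number from compound 2 to compound 3 (0.00 log units; within the scatter), nothing beyond the scatter. Compound 3 is estimated at 39000 nM, within a range of 15000 nM to 100000 nM.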

Compound 3, half-maximal inhibitory concentration: 780 nM
Beside the measured number, compound 3's estimate is 50-fold (1.70 log units) above it; measured number outside the range, below it.
By their numbers in this assay, from the lowest: compound 3; then compounds 1 and 2 (each within the scatter of the next).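

In this assay, the aryl group on an oxygen next to a carbonyl group proves sensitive to its substitution: the swap of methyl for methoxy stayed within the scatter, whereas the entry of 4-bromo-2-(methoxycarbonyl)phenyl gives a 50-fold lower number from compound 2 to compound 3 (1.70 log units; beyond the scatter). This group differs from the one it replaces in more than the bromine, since the carbon count also falls, so this single step cannot separate those two differences. Nothing available explains the drop.

From the compounds shown here alone, whether chlorine, a nitrile or an amine in place of the bromine would keep the lower number remains open.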